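This account rests on a few compounds, and the source may have more. Where it says the series, first, only, none or still open, it means among the compounds named here.

Measured so far:
compound 1, `Cc1ccc(S(=O)(=O)c2cnc3cc(Cl)ccc3c2N2CCC(C)CC2)cc1F` — 85%
compound 2, `Cc1ccc(S(=O)(=O)c2cnc3cc(F)ccc3c2N2CCC(C)CC2)cc1F` — 89%

In an assay on isolated protein for displacement of a labelled ligand from metabotropic glutamate receptor 5 (Homo sapiens), with a stated time of 60 min, tested at 1 uM (on this read-out lower numbers stand for less inhibition and higher numbers for more inhibition at the one concentration tested (going by the name of the read-out)), compound 1 gives 85%, the lowest of the two numbers shown, though only just: compound 2 gives 89%, and the step of a number 4 percentage points higher from compound 1 to compound 2 (within the scatter) lies within the usual scatter, so the two cannot be ranked against each other. Compound 3, `Cc1ccc(S(=O)(=O)c2cnc3cc(Cl)ccc3c2N2CCC(C)CC2)cc1C`, is not yet measured in this assay. It differs from compound 1 by one change: methyl in place of fluoro on an aromatic carbon. Within the data shown here, no measured step concerns a methyl in place of fluoro at this place; the only step available, a number 4 percentage points higher from compound 1 to compound 2 (within the scatter), touches a different position on the shared core and was itself within the scatter. Compound 1 therefore offers no grounds to expect a move beyond the scatter, and the step of no change at the digits printed from compound 1 to compound 3 (within the scatter) is what is expected. For compound 3 the estimate is 85%, with a range from 70% to 95%.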

Compound 3, a percentage reported as inhibition, at one concentration (the size of the read-out at that concentration, not a potency): 86%
Compound 3: the middle estimate sits 1 percentage points below what was measured; measured number inside the range.
By their numbers in this assay, from the lowest: compounds 1, 3 and 2 (each within the scatter of the next).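

In this assay, putting methyl in place of fluoro, which turns the 3-fluoro-4-methylphenyl into 3,4-dimethylphenyl, gives a number 1 percentage points higher from compound 1 to compound 3 (within the scatter). Among these compounds, this is the first reading at this place on the aromatic ring, and it shows that, with the chloro on the shared core kept, this assay does not separate fluoro from methyl here. No measurement is available to explain why these two groups read alike.

From the compounds shown here alone, whether a larger or more different group at this place, such as methoxy, an amine or a carboxylic acid, would read apart from compound 1 remains open. Going by these compounds, with a read-out at a single concentration, it is also open whether compound 1 and compound 3 would differ across a full concentration series.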